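The source may report more compounds than this note shows. Statements on the series, on what has been measured and on what is new or still open speak of the compounds shown alone.

Compound 1 `CS(=O)(=O)c1ccc(C(=O)NCCC(=O)N2CCCc3ccccc32)cc1[N+](=O)[O-]`; in an assay on isolated protein for inhibition of thyroid hormone receptor beta (Homo sapiens), read by fluorescence polarization (on this read-out higher numbers stand for weaker inhibition and lower numbers for stronger inhibition), compound 1 gives > 60000 nM, a limit of the assay.
Compound 2 `CS(=O)(=O)c1ccc(C(=O)NCCC(=O)N2CCc3ccccc32)cc1[N+](=O)[O-]`; in this assay compound 2 gives > 60000 nM, a limit of the assay.

Compound 2 thus stands only at a limit, not at a number. (the limit of > 60000 nM in this assay, at which 2 of the 2 values shown sit). Among the measured compounds shown here, the one measured step, a step that the two limits leave unreadable from compound 1 to compound 2, is the only comparison at hand and gives no readable size for a change on this carbonyl carbon. Compound 3 `CC(C)N(C(=O)CCNC(=O)c1ccc(S(C)(=O)=O)c([N+](=O)[O-])c1)C(C)C` carries the change (diisopropylamino in place of 2,3-dihydro-1H-indol-1-yl on a carbonyl carbon). For the measured compounds named here, with no measured step of readable size, no shift beyond the scatter is expected in this assay, and a further limit is the likeliest outcome; the step that the limit leaves unreadable from compound 2 to compound 3 is the estimate. Compound 3 is expected at 80000 nM, between 30000 nM and 200000 nM.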

Compound 3, half-maximal inhibitory concentration: > 60000 nM
Compound 3 was reported as a limit; the forecaster's own chance of this, stated with the estimate: 85%; the middle value lies beyond the limit too.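

No step to compound 3 can be read from compound 1 or compound 2, and no new comparison arises in this assay: the limit of > 60000 nM in this assay, at which 3 of the 3 values shown sit.

The compounds shown leave open whether any group on this carbonyl carbon gives a readable inhibition value.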